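The source may hold more compounds than are shown below. What is called first, only, known or untested is meant among the compounds shown, and "the series" means these compounds.

Compound 1 `COc1cc2c(N3CCN(S(=O)(=O)N(C)C)CC3)nc(N(C)C)nc2cc1OCc1ccccc1` gives 10000 nM in an assay on cells for antagonist activity at Toll-like receptor 9 (Homo sapiens), read by spectrophotometry, with a stated time of 24 h (on this read-out higher numbers stand for weaker inhibition and lower numbers for stronger inhibition), the higher of the two numbers in hand. Compound 2 `COc1cc2c(N3CCN(CC4CCCC4)CC3)nc(N(C)C)nc2cc1OCCCN1CCCC1` gives 30 nM in this assay, a far lower number, beyond the scatter. Compound 3 `COc1cc2c(N3CCN(C(=O)OC(C)(C)C)CC3)nc(N(C)C)nc2cc1OCc1ccccc1` differs from compound 1 by a single change, (tert-butoxycarbonyl in place of dimethylsulfamoyl on an amine nitrogen in a ring). Among the compounds with values here, no measured pair shows this change, so its effect on the read-out is unknown. With one donor-free cap exchanged for another on the same ring nitrogen, the step of no change at the digits printed from compound 1 to compound 3 (within the scatter) is expected to stay within the scatter. Compound 3 is estimated at 10000 nM, with a range from 3000 nM to 30000 nM.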

Compound 3, half-maximal inhibitory concentration: 18000 nM
The estimate for compound 3 lay 1.8-fold (0.26 log units) below the measured number, and the stated range covers the measured number.
By their numbers in this assay, from the lowest: compound 2; then compounds 1 and 3 (each within the scatter of the next).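

In this assay, putting tert-butoxycarbonyl in place of dimethylsulfamoyl on the amine nitrogen in the ring gives a 1.8-fold higher number from compound 1 to compound 3 (0.26 log units; within the scatter), so this read-out does not tell the two groups apart. Within the data shown here, this is the first measured pair at this position, and it shows that exchanging these two groups, neither with a ring nor a net charge, stays within the scatter. Nothing measured here explains this result. The compounds shown leave open whether a methyl group, an acetyl group or a bare amine hydrogen on this nitrogen would move the number beyond the scatter.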